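Pyridinyl Amide Replacing the Methoxyacetyl Group

A few compounds are considered here, and "the series" means these few. Any claim that something is new, unique, unknown or untested is made for them only; others in the source may bear on it.

Measured compounds in a functional assay (Sus scrofa) with sulfonylurea receptors; K-ATP channels (Homo sapiens) as the target; on this read-out higher numbers stand for an effect only at larger amounts of compound and lower numbers for an effect already at smaller amounts:
compound 1, `CCC(=O)Nc1c(C(O)(C(F)(F)F)C(F)(F)F)ccc2ccccc12`, gives 8.91 nM;
compound 2, `COCC(=O)Nc1c(C(O)(C(F)(F)F)C(F)(F)F)ccc2ccccc12`, gives 204 nM.

Compound 2 stands at the higher of the two numbers; its nearest neighbour is compound 1, from which the step of a 23-fold higher number from compound 1 to compound 2 (1.36 log units; beyond the scatter) reaches it. Compound 3, `O=C(Nc1c(C(O)(C(F)(F)F)C(F)(F)F)ccc2ccccc12)c1cccnc1`, differs from compound 2 by pyridin-3-yl in place of methoxymethyl on a carbonyl carbon. Within the data shown here, only one measured step touches this part of the shared core, the one from compound 1 to compound 2, and it was large; it shows that the amide substituent is sensitive to change but involves no ring, so it gives only a weak guide to an aromatic substituent. Compound 3 is therefore expected to move somewhat back towards compound 1, with wide uncertainty, the step of a 2.6-fold lower number from compound 2 to compound 3 (0.41 log units; beyond the scatter) being the estimate. Compound 3 is estimated at 80 nM, between 12 nM and 600 nM.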

Compound 3, half-maximal effective concentration: 617 nM
Compound 3: middle estimate off by 7.7-fold (0.89 log units), on the low side; measured number above the stated range.
By their numbers in this assay, from the lowest: compound 1; then compound 2; then compound 3.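

In this assay a ring on this carbonyl carbon brings no return towards compound 1: the change from methoxymethyl to pyridin-3-yl gives a 3.0-fold higher number from compound 2 to compound 3 (0.48 log units; beyond the scatter) and, set against the ethyl group, pyridin-3-yl gives a 69-fold higher number from compound 1 to compound 3 (1.84 log units; beyond the scatter) in all. Among these three groups on the carbonyl carbon, ethyl therefore has the lowest number, and both the ring-free methoxymethyl and the six-membered aromatic pyridin-3-yl lie above it beyond the usual scatter. Nothing at hand accounts for these differences.

On these data alone, what a phenyl group on this carbonyl carbon would give, and so whether the ring nitrogen of pyridin-3-yl matters, remains open. Also open, as far as these compounds go, is how a longer chain such as propyl, or a small ring such as cyclopropyl, would compare with ethyl.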